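Para-halogen swap on the aryl arm: fluoro to bromo

This account rests on a few compounds, and the source may have more. Where it says the series, first, only, none or still open, it means among the compounds named here.

Working notes on the series. Compound 1 `COc1ccc(-c2cn3ccnc3c(-c3ccc4ncn(C5CCCCC5)c4c3)n2)cc1` carries a 4-methoxyphenyl on the shared core, and in a functional assay on HCT-116 cells (Homo sapiens) for inhibition, read by sulforhodamine B assay, with a stated time of 48 h, tested at 10 uM (on this read-out higher numbers stand for more inhibition at the one concentration tested (going by the name of the read-out) and lower numbers for less inhibition), compound 1 gives 91.3%. Compound 2 `c1ccc2c(-c3cn4ccnc4c(-c4ccc5ncn(C6CCCCC6)c5c4)n3)cccc2c1` bears naphthalen-1-yl instead, and in this assay compound 2 gives 17.9%. Compound 3 `Fc1ccc(-c2cn3ccnc3c(-c3ccc4ncn(C5CCCCC5)c4c3)n2)cc1` carries 4-fluorophenyl, and in this assay compound 3 gives 18%. On these numbers compound 3 stands far below compound 1, the step being a number 73.3 percentage points lower from compound 1 to compound 3 (beyond the scatter), and level with compound 2, the step of a number 0.1 percentage points higher from compound 2 to compound 3 (within the scatter) lying within the scatter.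

Compound 4 `Brc1ccc(-c2cn3ccnc3c(-c3ccc4ncn(C5CCCCC5)c4c3)n2)cc1` differs from compound 3 by bromo in place of fluoro on an aromatic carbon. Going by the values given here, no measured step exchanges one halogen for another; the steps that bear on this position are a number 73.3 percentage points lower from compound 1 to compound 3 (beyond the scatter), where a polar group left, and a number 0.1 percentage points higher from compound 2 to compound 3 (within the scatter), where two quite different aryl groups gave the same low number. Both halogen analogues therefore point to a low read-out, and the expected step of a number 7 percentage points higher from compound 3 to compound 4 (within the scatter) is none beyond the scatter. The estimate for compound 4 in this assay is 25%, within 5% to 55%.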

Compound 4, a percentage reported as inhibition, at one concentration (the size of the read-out at that concentration, not a potency): 31.2%
Compound 4: the middle estimate sits 6.2 percentage points below what was measured; the range from low to high includes it.
By their numbers in this assay, from the lowest: compounds 2 and 3 (each within the scatter of the next); then compound 4; then compound 1.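

In this assay the halogen at this place is not interchangeable: the step is a number 13.2 percentage points higher from compound 3 to compound 4 (beyond the scatter), so the low level shared by compound 2 and compound 3 is not the lowest-lying outcome for every non-methoxy group but one that bromo rises from. The 4-bromophenyl group also stands apart from naphthalen-1-yl, the step being a number 13.3 percentage points higher from compound 2 to compound 4 (beyond the scatter), yet bromo remains far from what methoxy gives, the step being a number 60.1 percentage points lower from compound 1 to compound 4 (beyond the scatter). Nothing at hand accounts for these steps.

The compounds shown leave open whether the high number belongs to methoxy alone or would also appear with ethoxy, hydroxyl or dimethylamino at this place. As far as these compounds go, whether chloro would give a number nearer that of compound 3 or that of compound 4 also stays open.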